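Swapping One Pyridine Group on a Potent Growth Inhibitor

The compounds below may be only part of what the source reports. "The series", "measured", "known", "first", "only" and "open" are said of these compounds alone.

For the measured compounds named here, in a functional assay on PC-3 cells (Homo sapiens) for antiproliferative activity (a higher number here means a weaker inhibitor of growth, a lower number a stronger inhibitor of growth), compound 2 (`c1ccc(-c2cc(-c3ccsc3)cc(-c3ccccn3)n2)nc1`) gives 0.0017 ug/mL and stands lowest of the two numbers so far. Compound 1 (`c1ccc(-c2cc(-c3cccnc3)nc(-c3ccccn3)c2)cc1`) gives 0.28 ug/mL as the nearest number, well beyond the scatter. Compound 3 (`c1ccc(-c2cc(-c3ccsc3)cc(-c3cccnc3)n2)nc1`) carries pyridin-3-yl in place of pyridin-2-yl on an aromatic carbon and has not yet been measured. Compound 1 also carries pyridin-3-yl and gives the weaker 0.28 ug/mL so a loss of growth inhibition is the likelier outcome. A large step beyond the scatter is expected (a 59-fold higher number from compound 2 to compound 3 (1.77 log units; beyond the scatter)) in this assay toward a higher number. The estimated value for compound 3 is 0.1 ug/mL (expected range 0.012 ug/mL to 0.8 ug/mL).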

Compound 3, concentration for 50% growth inhibition: 0.054 ug/mL
For compound 3 the middle estimate is 1.9-fold (0.27 log units) above the measured one, within the range that was stated.
By their numbers in this assay, from the lowest: compound 2; then compound 3; then compound 1.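

In this assay the change from pyridin-2-yl to pyridin-3-yl, with the same atoms joined differently, brings a 32-fold higher number from compound 2 to compound 3 (1.50 log units; beyond the scatter) and shows that activity here depends on how the pyridine is attached, not merely on a pyridine being present. With pyridin-3-yl kept, thiophen-3-yl in place of phenyl gives a 5.2-fold lower number from compound 1 to compound 3 (0.71 log units; beyond the scatter) as a modest step. No measurement at hand explains why the pyridine change weighs so heavily.

Going by these compounds, how pyridin-4-yl or an amine at this position would compare with pyridin-2-yl remains open.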